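Dithiocarbamate-linked benzamides: N-substituent swap on the ring amine

The source may report more compounds than this note shows. Statements on the series, on what has been measured and on what is new or still open speak of the compounds shown alone.

Measured compounds:
compound 1, `Nc1ccccc1NC(=O)c1ccc(CSC(=S)N2CCc3ccccc32)cc1`: 25.7%
compound 2, `Cc1ccc(N2CCN(C(=S)SCc3ccc(C(=O)Nc4ccccc4N)cc3)CC2)cc1`: 25.8%

In a functional assay on A-375 cells (Homo sapiens) for antiproliferative activity, read by CCK-8 assay, with a stated time of 72 h, tested at 2 uM (a lower number here means a weaker effect, a higher number a stronger effect of the compound at the concentration tested), compound 1 gives 25.7% and compound 2 gives 25.8%. Among the measured compounds shown here, the two numbers lie within the usual scatter of one another, so no ranking separates compound 2 from compound 1; compound 2 simply sits alongside the one other measured compound, with no step between the two computed.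

Compound 3, `Nc1ccccc1NC(=O)c1ccc(CSC(=S)N2CCN(Cc3ccccc3)CC2)cc1`, is not yet measured in this assay. It is built from compound 2 by the change (benzyl in place of 4-methylphenyl on an amine nitrogen in a ring), a rearrangement of the same atoms in the group on the ring amine. For the measured compounds named here, no step between measured compounds is available to calibrate a change of this kind, and the only two values known are close together.

The step from compound 2 to compound 3 is expected to be a number 0.8 percentage points lower from compound 2 to compound 3 (within the scatter), that is, no change beyond the scatter. Compound 3 is therefore estimated at 25%, with a range from 12% to 40%.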

Compound 3, a percentage reported as inhibition, at one concentration (the size of the read-out at that concentration, not a potency): 10.6%
Estimate against measurement, compound 3: 14.4 percentage points above, outside the stated range (below it).
By their numbers in this assay, from the lowest: compound 3; then compounds 1 and 2 (each within the scatter of the next).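

In this assay, among the compounds shown here, the step of a number 15.2 percentage points lower from compound 2 to compound 3 (beyond the scatter) is the first one the series offers, and it shows that the group on the amine nitrogen in the ring is not a neutral site for this read-out. Benzyl and 4-methylphenyl have the same atoms and the same counts of rings, donors and acceptors, so the way these atoms are joined is enough to move the value beyond the scatter. No measurement on these compounds accounts for the difference.

As far as these compounds go, it remains open whether a phenethyl group, a plain methyl group or an acetyl group on this nitrogen would stand with compound 2 or with compound 3. The read-out comes from a single concentration, so it is also unknown whether this step would carry over to a difference in potency.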